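A few compounds are considered here, and "the series" means these few. Any claim that something is new, unique, unknown or untested is made for them only; others in the source may bear on it.

Among the measured compounds shown here, compound 2 `Cc1ccc(-c2cn(C[C@H](O)[C@H]3OC(=O)C(OCc4ccccc4)=C3OCc3ccccc3)nn2)cc1` stands at the lower end of the two numbers so far: in a functional assay on A549 cells (Homo sapiens) for antiproliferative activity, read by MTT assay, with a stated time of 72 h (a lower number here means a stronger inhibitor, a higher number a weaker inhibitor), compound 2 gives 8690 nM, whereas compound 1 `CCCCc1cn(C[C@H](O)[C@H]2OC(=O)C(OCc3ccccc3)=C2OCc2ccccc2)nn1` in this assay gives 28600 nM. For the measured compounds named here, the one step that connects them, a 3.3-fold lower number from compound 1 to compound 2 (0.52 log units; beyond the scatter), came from putting 4-methylphenyl in place of butyl on an aromatic carbon.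

Compound 3 `Cc1ccc(S(=O)(=O)NCc2cn(C[C@H](O)[C@H]3OC(=O)C(OCc4ccccc4)=C3OCc3ccccc3)nn2)cc1` keeps the shared core of compound 2 and changes only one place: (((4-methylphenyl)sulfonyl)amino)methyl in place of 4-methylphenyl on an aromatic carbon. Going by the values given here, no measured pair reproduces this change; the step from compound 1 to compound 2 concerns the same ring position but swaps a chain for an aryl group, not an aryl group for a larger, heteroatom-bearing arm. That step was modest in size, so the expectation for compound 3 rests on a single indirect comparison. With only that to go on, the number for compound 3 is expected to sit close to that of compound 2 or somewhat higher, the shift a 1.5-fold higher number from compound 2 to compound 3 (0.17 log units; within the scatter) being estimated as small. Compound 3 is therefore estimated in this assay at 13000 nM, with a range from 4000 nM to 40000 nM.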

Compound 3, half-maximal inhibitory concentration: 16800 nM
Beside the measured number, compound 3's estimate is 1.3-fold (0.11 log units) below it; low and high end bracket the measured number.
By their numbers in this assay, from the lowest: compounds 2, 3 and 1 (each within the scatter of the next, the first and the last beyond it).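

On the aromatic carbon of the five-membered aromatic ring with 3 nitrogen, the position takes (((4-methylphenyl)sulfonyl)amino)methyl in place of 4-methylphenyl with a 1.9-fold higher number from compound 2 to compound 3 (0.29 log units; within the scatter) in this assay, even though the entering group adds a hydrogen-bond donor and hydrogen-bond acceptors and is the larger of the two. The comparison with the butyl compound also stays within the scatter, with a 1.7-fold lower number from compound 1 to compound 3 (0.23 log units; within the scatter), so compound 3 cannot be told apart from either neighbour, although those two neighbours differ beyond the scatter, and it cannot be placed with one of them. Nothing available bears on why the sulfonamide-bearing arm reads this way.

The three compounds do not separate the parts of the new arm, so the sulfonyl group, the amino hydrogen, the methylene link and the 4-methylphenyl ring each remain unassessed on their own. On these data alone, it also remains open how this position would respond to a plain aminomethyl group, a carboxylic acid or a longer alkyl chain, and whether any such group would move the number beyond the scatter.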